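The source may report more compounds than this note shows. Statements on the series, on what has been measured and on what is new or still open speak of the compounds shown alone.

Measured so far:

compound 1, `CC#C[C@@H](Cc1nnn[nH]1)c1ccc(OCc2cc(F)c3scc(-c4ccc(OC)cc4C)c3c2)cc1`: 0.5 h
compound 2, `CC#C[C@@H](Cc1nnn[nH]1)c1ccc(OCc2ccc3sc(C(F)(F)F)c(-c4ccc(OCCOC)cc4C)c3c2)cc1`: a limit, > 3 h
compound 3, `CC#C[C@@H](Cc1nnn[nH]1)c1ccc(OCc2ccc3sc(Cl)c(-c4ccccc4C)c3c2)cc1`: 0.175 h

In an ADME assay on microsomes from liver (Homo sapiens) for metabolic stability (a lower number here means that the compound disappears faster, a higher number that the compound lasts longer), compound 1 gives 0.5 h and compound 3 gives 0.175 h. Compound 2 gives no number in this assay but only a limit, > 3 h, so compound 2 stands at the limit of > 3 h in this assay, at which 1 of the 3 values shown sits. Compound 4, `CC#C[C@@H](Cc1nnn[nH]1)c1ccc(OCc2ccc3sc(C)c(-c4ccc(OCCOC)cc4C)c3c2)cc1`, has not yet been measured in this assay. It differs from compound 2 in one place: methyl in place of trifluoromethyl on an aromatic carbon. Among the measured compounds shown here, no measured pair shows what this change does here, so the step is estimated rather than known. A decrease beyond the scatter is expected, giving a step of an at least 2.5-fold lower number from compound 2 to compound 4 (0.39 log units; beyond the scatter). Compound 4 is expected to reach about 1.2 h, most likely between 0.4 h and 3.5 h.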

Compound 4, half-life: 1.48 h
Compound 4: middle estimate off by 1.2-fold (0.09 log units), on the low side; low and high end bracket the measured number.
By their numbers in this assay, from the lowest: compound 3; then compound 1; then compound 4. At a limit, above all of these: compound 2.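

Among the compounds shown here, compounds 2 and 4 are the only pair here that differ solely at this position, the aromatic carbon next to the ring sulfur. In this assay, methyl in place of trifluoromethyl gives an at least 2.0-fold lower number from compound 2 to compound 4 (0.30 log units; that floor lies within the scatter). Compound 2 gives only a limit, > 3 h, so the true step may be larger, but this pair alone cannot establish a change beyond the scatter.

On these data alone, how an amine, a nitrile or an ethyl group would behave at this carbon remains open. So does whether this step would hold with a different group on the rest of the molecule.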